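Anilide ring substitution on the shared core: fluorine variant

The source may report more compounds than this note shows. Statements on the series, on what has been measured and on what is new or still open speak of the compounds shown alone.

Compound 1 `COc1ccc2c(=O)c(/C=C/C(=O)Nc3cccc(Cl)c3)coc2c1` carries a 3-chlorophenyl group on the amide nitrogen of the shared core. In a functional assay on HeLa cells (Homo sapiens) for inhibition, read by MTT assay, with a stated time of 48 h (on this read-out higher numbers stand for weaker inhibition and lower numbers for stronger inhibition), compound 1 gives 11900 nM, the second highest of the three numbers measured. Compound 2 `COc1cccc(NC(=O)/C=C/c2coc3cc(OC)ccc3c2=O)c1` gives 19200 nM, and compound 3 `COc1ccc2c(=O)c(/C=C/C(=O)Nc3ccccc3C)coc2c1` gives 7270 nM. The step of a 1.6-fold higher number from compound 1 to compound 2 (0.21 log units; within the scatter) and the step of a 1.6-fold lower number from compound 1 to compound 3 (0.21 log units; within the scatter) both stay within the scatter, while a 2.6-fold lower number from compound 2 to compound 3 (0.42 log units; beyond the scatter) is a modest step beyond it.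

Compound 4 `COc1ccc2c(=O)c(/C=C/C(=O)Nc3ccc(F)cc3)coc2c1` is not yet measured; it differs from compound 1 as follows: 4-fluorophenyl in place of 3-chlorophenyl on an amide-type nitrogen. Within the data shown here, no measured step exchanges the chlorine for fluorine or moves a substituent around the anilide ring in this way, so the closest reference remains the pair of near-null steps from compound 1 to compound 2 and from compound 1 to compound 3, which together suggest that changes on this ring have so far shifted this assay little. Compound 4 is therefore expected to stay within the scatter of compound 1, with an estimated step of a 1.1-fold higher number from compound 1 to compound 4 (0.04 log units; within the scatter). The estimate for compound 4 is 13000 nM, expected between 5000 nM and 35000 nM.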

Compound 4, half-maximal inhibitory concentration: 9680 nM
The estimate for compound 4 lay 1.3-fold (0.13 log units) above the measured number; measured number inside the range.
By their numbers in this assay, from the lowest: compounds 3, 4, 1 and 2 (each within the scatter of the next, the first and the last beyond it).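

Notes on the 4-fluorophenyl change: in this assay, the 4-fluorophenyl anilide shows no step beyond the scatter against any of the three other anilides (a 1.2-fold lower number from compound 1 to compound 4 (0.09 log units; within the scatter)) and (a 1.3-fold higher number from compound 3 to compound 4 (0.12 log units; within the scatter)) and (a 2.0-fold lower number from compound 2 to compound 4 (0.30 log units; within the scatter)). Among these compounds, compound 4 thus lies within the scatter of both compound 2 and compound 3, so the only step beyond the scatter in this set remains the one between those two (a 2.6-fold lower number from compound 2 to compound 3 (0.42 log units; beyond the scatter)). No measured evidence bears on the reason for this flat reading.

Fluorine replaces chlorine here while the substituent's place on the ring also changes, so the compounds shown do not separate these two changes. As far as these compounds go, it remains open whether an amine or a carboxylic acid on the phenyl ring, or a longer chain in place of that ring, would move this read-out further.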